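Aryl amide variation on a shared pyrazole core

The source may report more compounds than this note shows. Statements on the series, on what has been measured and on what is new or still open speak of the compounds shown alone.

Compound 1 `O=C(Nc1cc(-c2ccccc2)nn1-c1ccccc1)c1cccc(C(F)(F)F)c1` and compound 2 `O=C(Nc1cc(-c2ccccc2)nn1-c1ccccc1)c1ccc([N+](=O)[O-])cc1` share the same core and differ only in the aryl group on the carbonyl carbon. In an assay on HEK293 cells for displacement of a labelled ligand from metabotropic glutamate receptor 5 (Rattus norvegicus) (a lower number here means a stronger inhibitor, a higher number a weaker inhibitor), compound 1 gives 1650 nM, while compound 2 gives 250 nM. Among the compounds with values here, the one step measured so far, a 6.6-fold lower number from compound 1 to compound 2 (0.82 log units; beyond the scatter), shows that the aryl group on the carbonyl carbon moves the number well beyond the scatter. Compound 2 therefore stands lowest of the two numbers; its nearest neighbour is compound 1, with a number that is higher by the step just given.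

Compound 3 `COc1cc(OC)cc(C(=O)Nc2cc(-c3ccccc3)nn2-c2ccccc2)c1` is not yet measured. It differs from compound 2 in one place: 3,5-dimethoxyphenyl in place of 4-nitrophenyl on a carbonyl carbon. Within the data shown here, no measured step covers this exact exchange; the only step that bears on it, the one from compound 1 to compound 2, shows that the same position is sensitive and that an aryl group without the nitro substituent gave the higher number. The expectation for compound 3 is therefore a higher number than compound 2 in this assay, by a 3.2-fold higher number from compound 2 to compound 3 (0.51 log units; beyond the scatter). The estimate for compound 3 is 800 nM, with a range from 250 nM to 2500 nM.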

Compound 3, inhibition constant: > 10000 nM
Compound 3 gave a limit, no number (the forecaster's own chance of this, stated with the estimate: 10%); middle value at least 12-fold (1.09 log units) away from the limit.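

Compound 3 in this assay gives > 10000 nM, a limit of the assay and not a number, and the only such reading in the series so far: the limit of > 10000 nM in this assay, at which 1 of the 3 values shown sits.

Exchange of the 4-nitrophenyl group for 3,5-dimethoxyphenyl gives an at least 40-fold higher number from compound 2 to compound 3 (1.60 log units; beyond the scatter), so the aryl group on the carbonyl carbon can move the number much further than the first pair showed, even though the groups that leave and enter have the same counts of hydrogen-bond donors and acceptors. Compound 3 also separates from the earlier, higher-numbered compound, with an at least 6.0-fold higher number from compound 1 to compound 3 (0.78 log units; beyond the scatter), which puts the three aryl groups in a single order beyond the scatter, with 3,5-dimethoxyphenyl giving the highest number.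

The compounds shown leave open whether the methoxy groups as such, or their number and placing, account for the change, a question that a 4-methoxyphenyl or 3-methoxyphenyl group on the carbonyl carbon would address. Also open, on these data alone, are how far past its limit compound 3 lies and whether the low number of compound 2 is specific to the nitro group or is shared by a 4-cyanophenyl group.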